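A benzyl(methyl)amino swap on the shared core

The compounds below may be only part of what the source reports. "The series", "measured", "known", "first", "only" and "open" are said of these compounds alone.

Compound 1 `OC[C@H]1O[C@@H](n2cnc3c(Cn4ccc5ccccc54)ncnc32)[C@H](O)[C@@H]1O`: 3400 nM
Compound 2 `OC[C@H]1O[C@@H](n2cnc3c(CSCc4ccccc4)ncnc32)[C@H](O)[C@@H]1O`: 9200 nM
Compound 3 `OC[C@H]1O[C@@H](n2cnc3c(COc4ccccn4)ncnc32)[C@H](O)[C@@H]1O`: 16600 nM

In a functional assay on CCRF-CEM cells (Homo sapiens) for inhibition, with a stated time of 72 h (on this read-out lower numbers stand for stronger inhibition and higher numbers for weaker inhibition), compound 3 gives 16600 nM. The smallest step reaching it is a 1.8-fold higher number from compound 2 to compound 3 (0.26 log units; within the scatter), and the widest is a 4.9-fold higher number from compound 1 to compound 3 (0.69 log units; beyond the scatter). Compound 4 `CN(Cc1ccccc1)Cc1ncnc2c1ncn2[C@@H]1O[C@H](CO)[C@@H](O)[C@H]1O` differs from compound 3 by one change on a saturated chain carbon bound to an aromatic carbon: benzyl(methyl)amino in place of (pyridin-2-yl)oxy on a saturated chain carbon bound to an aromatic carbon. Among the compounds with values here, no measured step makes this exact exchange. The nearest guide is compound 2, whose benzylsulfanyl group gives 9200 nM, so a modest move towards a lower number is expected. The estimated step is a 2.0-fold lower number from compound 3 to compound 4 (0.29 log units; within the scatter), which is no larger than the widest measured one. For compound 4 the expected value is 8500 nM, with an estimated range of 2800 nM to 24000 nM.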

Compound 4, half-maximal inhibitory concentration: 20300 nM
For compound 4 the middle estimate is 2.4-fold (0.38 log units) below the measured one, within the range that was stated.
By their numbers in this assay, from the lowest: compound 1; then compounds 2, 3 and 4 (each within the scatter of the next, the first and the last beyond it).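

In this assay benzyl(methyl)amino on a saturated chain carbon bound to an aromatic carbon cannot be told apart from (pyridin-2-yl)oxy (a 1.2-fold higher number from compound 3 to compound 4 (0.09 log units; within the scatter)). Keeping a benzyl group does not keep the number of compound 2 (a 2.2-fold higher number from compound 2 to compound 4 (0.34 log units; beyond the scatter)), and the gap to the 1H-indol-1-yl group of compound 1 is wider still (a 6.0-fold higher number from compound 1 to compound 4 (0.78 log units; beyond the scatter)). Nothing available explains these steps.

Open is whether the methyl on the nitrogen matters, since a benzylamino group without it is not among these compounds. Also open, from the compounds shown here alone, is how a benzyloxy group would compare with benzylsulfanyl at this place.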